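Does compound 3 fall back towards compound 1?

The source may report more compounds than this note shows. Statements on the series, on what has been measured and on what is new or still open speak of the compounds shown alone.

Two close relatives frame this question. In an ADME assay on microsomes from liver (Mus musculus) for metabolic stability, read by HPLC, with a stated time of 4 h (a higher number here means that the compound lasts longer, a lower number that the compound disappears faster), compound 1 `CN(C)c1ccc2cc(-c3cc(Cl)cc(Cl)c3)c(N)nc2c1` gives 0.17 h. Compound 2 `CNc1ccc2cc(-c3cc(Cl)cc(Cl)c3)c(N)nc2c1` gives > 4 h in this assay, and this is a limit of the assay, not a number. The next structure, compound 3 `Nc1nc2cc(N3CCCC3)ccc2cc1-c1cc(Cl)cc(Cl)c1`, differs from compound 2 as follows: pyrrolidin-1-yl in place of methylamino on an aromatic carbon. In words, pyrrolidin-1-yl stands in place of methylamino on an aromatic carbon, so the nitrogen there no longer carries a hydrogen. Within the data shown here, one measured step bears on this change: an at least 23-fold higher number from compound 1 to compound 2 (1.37 log units; beyond the scatter). Compound 1 also has no hydrogen on that nitrogen and gives 0.17 h, so a large drop is expected in this assay. Among the measured compounds shown here, one step is thin evidence, and the five-membered ring has no measured counterpart here, so the range stays wide. The expected size of the change is an at least 13-fold lower number from compound 2 to compound 3 (1.12 log units; beyond the scatter). For compound 3 the estimated half-life is 0.3 h, with an expected range of 0.08 h to 1.5 h.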

Compound 3, half-life: 0.2 h
The estimate for compound 3 lay 1.5-fold (0.18 log units) above the measured number; low and high end bracket the measured number.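

In this assay, pyrrolidin-1-yl in place of methylamino gives an at least 20-fold lower number from compound 2 to compound 3 (1.30 log units; beyond the scatter), so a second group whose nitrogen carries no hydrogen also stands far from compound 2. The size of that step rests on a limit of the assay, not on a number: the limit of > 4 h in this assay, at which 1 of the 3 values shown sits. Pyrrolidin-1-yl in place of dimethylamino gives a 1.2-fold higher number from compound 1 to compound 3 (0.07 log units; within the scatter), which lies within the scatter, so in this set of three the ring and the two separate methyl groups cannot be told apart, and only compound 2, with its hydrogen on that nitrogen, stands apart.

That pattern rests on compound 2 alone, so the hydrogen may or may not be what matters. An ethylamino group or a plain amine on the same aromatic carbon would test whether the pattern holds for other groups that keep a hydrogen on that nitrogen.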